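A few compounds are considered here, and "the series" means these few. Any claim that something is new, unique, unknown or untested is made for them only; others in the source may bear on it.

Measured so far in a functional assay on HEL cells (Homo sapiens); a lower number here means that less compound is tolerated, a higher number that more compound is tolerated:
compound 1, `Cc1cn([C@@H]2O[C@H](CO[Si](C)(C)C(C)(C)C)[C@@]3(OS(=O)(=O)C=C3NCC(=O)O)[C@H]2O[Si](C)(C)C(C)(C)C)c(=O)n(C)c1=O`, gives 136000 nM;
compound 2, `Cc1cn([C@@H]2O[C@H](CO[Si](C)(C)C(C)(C)C)[C@@]3(OS(=O)(=O)C=C3NCC(=O)C(=O)O)[C@H]2O[Si](C)(C)C(C)(C)C)c(=O)n(C)c1=O`, gives 146000 nM.

Among the compounds with values here, of these two numbers, compound 2 holds the higher one, but the only step measured, a 1.1-fold higher number from compound 1 to compound 2 (0.03 log units; within the scatter), stays within the scatter, so the two compounds cannot be told apart. Compound 3, `Cc1cn([C@@H]2O[C@H](CO[Si](C)(C)C(C)(C)C)[C@@]3(OS(=O)(=O)C=C3NCCC(N)=O)[C@H]2O[Si](C)(C)C(C)(C)C)c(=O)n(C)c1=O`, differs from compound 2 in this way: carbamoylmethyl in place of carboxycarbonyl on a saturated chain carbon bound to an amine nitrogen. Within the data shown here, only that single small step bears on the change, and nothing beyond the scatter is therefore expected in this assay in either direction; the step expected is a 1.0-fold lower number from compound 2 to compound 3 (0.02 log units; within the scatter). Compound 3 is estimated at 140000 nM, with a range from 65000 nM to 300000 nM.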

Compound 3, half-maximal cytotoxic concentration: 14800 nM
The estimate for compound 3 lay 9.5-fold (0.98 log units) above the measured number; measured number below the stated range.
By their numbers in this assay, from the lowest: compound 3; then compounds 1 and 2 (each within the scatter of the next).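

In this assay, the group on the saturated chain carbon bound to the amine nitrogen proved able to shift the number beyond the scatter, which the carboxy and carboxycarbonyl pair had not shown. Carbamoylmethyl in place of carboxycarbonyl gives a 9.9-fold lower number from compound 2 to compound 3 (0.99 log units; beyond the scatter), and carbamoylmethyl in place of carboxy gives a 9.2-fold lower number from compound 1 to compound 3 (0.96 log units; beyond the scatter). No evidence at hand explains this shift.

The compounds shown leave open whether the terminal amide or the chain carrying it accounts for the step. A 2-carboxyethyl group on the amine nitrogen, or a carbamoylmethyl group there, would separate the two.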